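From pyridin-3-yl to 1,3-benzothiazol-5-yl: a clearance estimate

A few compounds are considered here, and "the series" means these few. Any claim that something is new, unique, unknown or untested is made for them only; others in the source may bear on it.

Compound 3 `Nc1ccc(S(=O)(=O)N2CCN(c3ncc(C(O)(C(F)(F)F)C(F)(F)F)cc3-c3cccnc3)CC2)cn1` gives 17 mL.min-1.g-1 in an ADME assay (liver) for metabolic stability, with Liver microsome (Homo sapiens) as the target, using microsomes and NADPH, with a stated time of 30 min, tested at 1 uM; on this read-out higher numbers stand for fast clearance and lower numbers for slow clearance. Compound 2 `Nc1ccc(S(=O)(=O)N2CCN(c3ncc(C(O)(C(F)(F)F)C(F)(F)F)cc3-c3ccccc3O)CC2)cn1` gives 22 mL.min-1.g-1, and a 1.3-fold lower number from compound 2 to compound 3 (0.11 log units; within the scatter) places the two together. Compound 1 `Nc1ccc(S(=O)(=O)N2CCN(c3ncc(C(O)(C(F)(F)F)C(F)(F)F)cc3-c3ccoc3)CC2)cn1` gives < 14 mL.min-1.g-1, which is a limit of the assay and not a number.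

Compound 4 `Nc1ccc(S(=O)(=O)N2CCN(c3ncc(C(O)(C(F)(F)F)C(F)(F)F)cc3-c3ccc4scnc4c3)CC2)cn1` has not yet been measured. It carries 1,3-benzothiazol-5-yl in place of pyridin-3-yl on an aromatic carbon. Two further steps at this aromatic carbon bear on the change: an at least 1.5-fold higher number from compound 1 to compound 2 (0.19 log units; that floor lies within the scatter) and an at least 1.2-fold higher number from compound 1 to compound 3 (0.08 log units; that floor lies within the scatter). Both are floors rather than full sizes, so neither measured swap from compound 1 is shown beyond the scatter, and neither is the step between compound 2 and compound 3. Going by the values given here, no measured compound carries the entering group, so the expectation stays loose.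

The starting point is compound 3 at 17 mL.min-1.g-1. The expected change is a 1.4-fold higher number from compound 3 to compound 4 (0.15 log units; within the scatter), which would stay within the scatter. For compound 4 the estimated value is 24 mL.min-1.g-1, with an expected range of 14 mL.min-1.g-1 to 50 mL.min-1.g-1.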

Compound 4, intrinsic clearance in microsomes: 39 mL.min-1.g-1
Compound 4: the middle estimate sits 1.6-fold (0.21 log units) below what was measured; low and high end bracket the measured number.
By their numbers in this assay, from the lowest: compounds 3, 2 and 4 (each within the scatter of the next, the first and the last beyond it). At a limit, below all of these: compound 1.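

In this assay, 1,3-benzothiazol-5-yl gives the first step at this aromatic carbon that is fully shown to lie beyond the scatter, measured against pyridin-3-yl (a 2.3-fold higher number from compound 3 to compound 4 (0.36 log units; beyond the scatter)), while against 2-hydroxyphenyl the step stays within it (a 1.8-fold higher number from compound 2 to compound 4 (0.25 log units; within the scatter)). Against furan-3-yl the step also clears the scatter (an at least 2.7-fold higher number from compound 1 to compound 4 (0.44 log units; beyond the scatter)), whereas the earlier floors from that group did not. Compound 1 sits at a limit, so this step has a floor and no full size: the limit of < 14 mL.min-1.g-1 in this assay, at which 1 of the 4 values shown sits.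

The compounds shown cannot separate the part played by the second ring of 1,3-benzothiazol-5-yl from that of its sulfur atom. A quinolin-6-yl group, with two fused rings and no sulfur, or a thiazol-5-yl group, with sulfur and one ring, would bear on that question at this carbon.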